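Series notes: from compound 1 to compound 3

A few compounds are considered here, and "the series" means these few. Any claim that something is new, unique, unknown or untested is made for them only; others in the source may bear on it.

Measured in a functional assay on T98G cells (Homo sapiens) for inhibition, read by colorimetric assay and MTT assay, with a stated time of 72 h (on this read-out higher numbers stand for weaker inhibition and lower numbers for stronger inhibition), so far:
- compound 1 `C=CCCCCOc1ccccc1-c1cnc(OCCC=C)n1C` gives 29000 nM as its value
- compound 2 `C=CCCCCOc1ccc(C)cc1-c1cnc(OCCC=C)n1C` gives 94000 nM as its value

Among the measured compounds shown here, compound 1 holds the lower of the two numbers and is therefore the stronger inhibitor of this pair, though only two values are available. Compound 3 `C=CCCCCOc1ccccc1-c1cnc(OCCCC=C)n1C` has not yet been measured. It keeps the core of compound 1 and differs in a single chain: allyl in place of vinyl on a saturated chain carbon, two bonds along the chain from an oxygen on an aromatic ring and the same difference, cut one bond further out, reads (but-3-en-1-yl)oxy to (pent-4-en-1-yl)oxy.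

For the measured compounds named here, only one measured step is available, and it is modest: a 3.2-fold higher number from compound 1 to compound 2 (0.51 log units; beyond the scatter) in this series. That step is methyl in place of hydrogen on an aromatic carbon, so it lies elsewhere on the structure and is a different kind of change. Going by the values given here, no measured step tests chain length, and the data give no direction for this change. It serves only as a rough guide to size. In this assay, among the compounds with values here, no step beyond the scatter is therefore expected, although a step as large as the one to compound 2 cannot be excluded.

The expected outcome is a 1.1-fold higher number from compound 1 to compound 3 (0.04 log units; within the scatter) in this assay. For compound 3 the estimated value is 32000 nM within an expected range of 13000 nM to 80000 nM on current evidence.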

Compound 3, half-maximal inhibitory concentration: 3000 nM
For compound 3 the middle estimate is 11-fold (1.03 log units) above the measured one; the measured number lies below the stated range.
By their numbers in this assay, from the lowest: compound 3; then compound 1; then compound 2.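

Lengthening (but-3-en-1-yl)oxy to (pent-4-en-1-yl)oxy on the shared core is the first measured test of chain length at this position. In this assay, among the compounds shown here, the change gives a 9.7-fold lower number from compound 1 to compound 3 (0.99 log units; beyond the scatter) and so moves towards stronger inhibition, whereas the only earlier step, a 3.2-fold higher number from compound 1 to compound 2 (0.51 log units; beyond the scatter) on an aromatic carbon, moved towards weaker inhibition and said nothing about this chain. The position therefore responds to a change that, by the computed counts, is limited to allyl with 3 heavy atoms in place of vinyl with 2, with the double bond outside aromatic rings kept and no hydrogen-bond donors or acceptors entering. Nothing on hand accounts for the size or direction of this step.

With only the two chain lengths shown at this position, it remains open whether a longer chain would continue the trend in this assay or reverse it, and whether the terminal double bond matters, which a saturated pentyl chain or a terminal amine would test. Also open, as far as these compounds go, is whether methyl on the aromatic carbon would have the same effect when combined with the (pent-4-en-1-yl)oxy chain.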